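Working notes: methoxy to methanesulfonamido in the series

This account rests on a few compounds, and the source may have more. Where it says the series, first, only, none or still open, it means among the compounds named here.

Measured so far in an ADME assay on L6 cells (Rattus norvegicus) for cytotoxicity, read by resazurin assay, with a stated time of 72 h (on this read-out higher numbers stand for weaker inhibition and lower numbers for stronger inhibition), are these:
- compound 1 (`[O-][n+]1cncc(C(O)(c2ccc(Cl)cc2)c2ccccc2Cl)c1`) gives > 100000 nM as a limit of the assay
- compound 2 (`COc1ccc(C(O)(c2ccc(Cl)cc2)c2cccnc2)cc1`) gives 68100 nM as a number

Within the data shown here, compound 2 holds the only actual number in this assay so far. For compound 1 the result is only a limit (the limit of > 100000 nM in this assay, at which 1 of the 2 values shown sits).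

Compound 3 (`CS(=O)(=O)Nc1ccc(C(O)(c2ccc(Cl)cc2)c2cccnc2)cc1`) has methanesulfonamido in place of methoxy on an aromatic carbon, para to a large group (methanesulfonamido in place of methoxy on an aromatic carbon). Among the measured compounds shown here, no measured step covers this change. With compound 2 at 68100 nM as the only anchor, no shift beyond the usual scatter is expected, and any drift should lean toward weaker inhibition. What is expected here is a 1.1-fold higher number from compound 2 to compound 3 (0.04 log units; within the scatter) and thus a small step. The estimated value for compound 3 is 75000 nM with a range from 30000 nM to 100000 nM expected.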

Compound 3, half-maximal inhibitory concentration: > 100000 nM
Compound 3 ended at the assay's limit; the forecaster's own chance of this, stated with the estimate: 40%; at least 1.3-fold (0.12 log units) between middle value and limit.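

In this assay, among these compounds, the one step at this position, the aromatic carbon para to a large group, gives an at least 1.4-fold higher number from compound 2 to compound 3 (0.16 log units; that floor lies within the scatter) for methanesulfonamido in place of methoxy. This change does not move the read-out toward stronger inhibition, a reading that compounds 1 and 2 could not give, as they differ in more than one place. Compound 3 stands at a limit of the assay, so the full size of the step cannot be read: the limit of > 100000 nM in this assay, at which 2 of the 3 values shown sit.

The compounds shown leave open how an amine, a carboxylic acid or a longer alkoxy chain would read at this position. They also leave open whether methanesulfonamido in place of methoxy would read the same way on the core of compound 1.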